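A few compounds are considered here, and "the series" means these few. Any claim that something is new, unique, unknown or untested is made for them only; others in the source may bear on it.

Working notes on the series. Compound 1 `COC(=O)Cn1cc(CO[C@H]2CC(=O)[C@@H]3OC[C@H]2O3)nn1` is the reference point: in a functional assay on MDA-MB-231 cells (Homo sapiens) for cytotoxicity, read by MTT assay, with a stated time of 48 h (on this read-out higher numbers stand for weaker inhibition and lower numbers for stronger inhibition), compound 1 gives 21300 nM, the smallest of the three numbers shown, though compounds 2 and 3 both lie within the scatter of it. Compound 2 `O=C1C[C@H](OCc2cn(-c3ccccc3Cl)nn2)[C@H]2CO[C@@H]1O2` gives 26400 nM in this assay, and compound 3 `O=C1C[C@H](OCc2cn(-c3cccc(Cl)c3Cl)nn2)[C@H]2CO[C@@H]1O2` gives 26000 nM. The measured steps are all small: a 1.2-fold higher number from compound 1 to compound 2 (0.09 log units; within the scatter), a 1.2-fold higher number from compound 1 to compound 3 (0.09 log units; within the scatter), and a 1.0-fold lower number from compound 2 to compound 3 (0.01 log units; within the scatter). Nothing here leaves the scatter.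

Compound 4 `COc1ccc(Cn2cc(CO[C@H]3CC(=O)[C@@H]4OC[C@H]3O4)nn2)cc1` has not yet been measured. It differs from compound 1 in one place: 4-methoxyphenyl in place of methoxycarbonyl on a saturated chain carbon bound to an aromatic nitrogen. Among the compounds with values here, the steps that bear on this are the two from compound 1, in which the entire (methoxycarbonyl)methyl group on the aromatic nitrogen is exchanged for a chlorinated phenyl without the number moving beyond the scatter; the step from compound 2 to compound 3 adds a chloro and is equally flat. Exchanging only the methoxycarbonyl part for 4-methoxyphenyl is a change of similar scope, so no step beyond the scatter is expected in either direction, which is the expected 1.1-fold higher number from compound 1 to compound 4 (0.05 log units; within the scatter) in this assay. The estimate for compound 4 in this assay is therefore 24000 nM, with an expected range from 12000 nM to 48000 nM.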

Compound 4, half-maximal inhibitory concentration: 34800 nM
Estimate against measurement, compound 4: 1.5-fold (0.16 log units) below, within the range that was stated.
By their numbers in this assay, from the lowest: compounds 1, 3, 2 and 4 (each within the scatter of the next).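

In this assay, the exchange of methoxycarbonyl for 4-methoxyphenyl on a saturated chain carbon bound to an aromatic nitrogen stays within the scatter (a 1.6-fold higher number from compound 1 to compound 4 (0.21 log units; within the scatter)), although the entering group has 8 heavy atoms and one six-membered aromatic ring of carbon only, while the leaving group has 4 heavy atoms and no ring. Compounds 2 and 3 replaced the whole (methoxycarbonyl)methyl group, so only compound 4 shows that an aromatic ring can be carried on the retained chain carbon without a step beyond the scatter, and that the loss of the carbonyl and ester oxygens there does the same. No measurement shown gives a reason for the size of this step.

The compounds shown leave open whether any group on this chain carbon moves the number beyond the scatter, for example a carboxylic acid, a primary amine or a longer alkyl chain in place of methoxycarbonyl. They also leave open what the methoxy on the ring of compound 4 contributes, which a plain phenyl on the same chain carbon would address.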